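The source may report more compounds than this note shows. Statements on the series, on what has been measured and on what is new or still open speak of the compounds shown alone.

For the measured compounds named here, in a functional assay (Hepatocyte) for inhibition, with Rattus norvegicus as the target (a lower number here means a stronger inhibitor, a higher number a weaker inhibitor), compound 2 (`CC(C)(CCCCCCCCCCCCCCCCC(C)(C)CC(=O)O)CC(=O)O`) gives 400000 nM, the highest of the three numbers so far, which makes it the weakest inhibitor of the group. Compound 1 (`CC(C)(CCCCCCCCCCCCC(C)(C)CC(=O)O)CC(=O)O`) gives 150000 nM and compound 3 (`CC(C)(CCCCCCCCC(C)(C)CC(=O)O)CC(=O)O`) gives 100000 nM, both clearly lower than compound 2. All three carry the same end groups on a saturated chain, and compound 2 has the longest chain.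

Compound 4 (`CC(C)(CCCCCCCCCCCCCCC(C)(C)CC(=O)O)CC(=O)O`) has not yet been measured. The change from compound 2 is 1-(carboxymethyl)-1-methylethyl in place of 3-(carboxymethyl)-3-methylbutyl on a saturated chain carbon, ten or more bonds along the chain from a carbonyl carbon. This shortens the chain, yet it stays longer than in compound 1, which gives 150000 nM. A modest move toward a lower number, and so a somewhat stronger inhibitor, therefore seems likely. The expected step of a 1.6-fold lower number from compound 2 to compound 4 (0.20 log units; within the scatter) is small and may not clear the usual scatter. The estimated value for compound 4 is 250000 nM, with an expected range of 120000 nM to 500000 nM.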

Compound 4, half-maximal inhibitory concentration: 300000 nM
Compound 4: the middle estimate sits 1.2-fold (0.08 log units) below what was measured; the measured number falls inside the stated range.
By their numbers in this assay, from the lowest: compounds 3, 1, 4 and 2 (each within the scatter of the next, the first and the last beyond it).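

In this assay, placing 1-(carboxymethyl)-1-methylethyl in place of 3-(carboxymethyl)-3-methylbutyl on a saturated chain carbon, ten or more bonds along the chain from a carbonyl carbon, gives a step within the scatter (a 1.3-fold lower number from compound 2 to compound 4 (0.12 log units; within the scatter)), and the opposite exchange gives another (a 2.0-fold higher number from compound 1 to compound 4 (0.30 log units; within the scatter)). Compound 4 therefore cannot be separated from compound 1 or compound 2, although those two lie beyond the scatter of each other, so a single exchange of this size is too small to read on its own here. Nothing measured here explains why these numbers fall as they do.

The compounds shown leave open how a chain shorter than that of compound 3 would behave. They also leave open whether an ether oxygen within the chain, or an amide at its ends, would shift the number.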